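Hydroxy tetralone series: chloro for fluoro on the aryl ring

The compounds below may be only part of what the source reports. "The series", "measured", "known", "first", "only" and "open" are said of these compounds alone.

Measured compounds and values:
compound 1, `O=C1/C(=C/c2ccccc2Cl)CCc2c(O)cccc21`, 1280 nM
compound 2, `O=C1/C(=C/c2ccccc2Cl)CCc2cc(O)ccc21`, 1910 nM
compound 3, `O=C1/C(=C/c2ccc(F)cc2)CCc2ccc(O)cc21`, 840 nM

All three were run in a functional assay on RAW264.7 cells (Mus musculus) for inhibition; a higher number here means a weaker inhibitor, a lower number a stronger inhibitor. Compound 3 carries the smallest of the three numbers; its gap to compound 1 lies within the scatter, so no order between those two can be read, whereas its gap to compound 2 lies beyond the scatter. No pair of these compounds differs in one place only, so no single-change step is available; compounds 1 and 2 differ from compound 3 both in the position of the hydroxyl on the shared core and in the halogen and its place on the aryl ring.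

The next compound, compound 4, `O=C1/C(=C/c2ccc(Cl)cc2)CCc2ccc(O)cc21`, is compound 3 with chloro in place of fluoro on an aromatic carbon. Among the measured compounds shown here, with no matched step to draw on, the expectation rests on the narrow spread of the three numbers: the step from compound 3 to compound 4 in this assay is estimated at a 1.2-fold lower number from compound 3 to compound 4 (0.08 log units; within the scatter), which is no change beyond the scatter. Compound 4 is therefore expected at 700 nM, with a range from 300 nM to 1600 nM.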

Compound 4, half-maximal inhibitory concentration: 1100 nM
Estimate against measurement, compound 4: 1.6-fold (0.20 log units) below, within the range that was stated.
By their numbers in this assay, from the lowest: compounds 3, 4, 1 and 2 (each within the scatter of the next, the first and the last beyond it).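

Working notes: this is the first single-change step in the series. In this assay, chloro in place of fluoro on an aromatic carbon, para to a large group, gives a 1.3-fold higher number from compound 3 to compound 4 (0.12 log units; within the scatter) as the step on the shared core. At this place, then, the two halogens cannot be told apart by this read-out, and no order can be given between compound 3 and compound 4. The halogen can be exchanged here without a change that rises above the scatter, at least for this one pair.

Going by these compounds, whether a methoxy, a trifluoromethyl or an amine at this place would shift the number beyond the scatter remains open. Compound 1 and compound 2 still have no single-change partner, so the place of the hydroxyl on the core also remains unresolved. No measurement at hand speaks to what lies behind this step.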